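The source may hold more compounds than are shown below. What is called first, only, known or untested is meant among the compounds shown, and "the series" means these compounds.

Of the compounds shown here, three built on one shared core have so far been tested in a functional assay on the whole organism (strain Wister albino) for inhibition, with Rattus norvegicus as the target, read by paw edema, with stated times of 1 h and 3 h, at a dose of 50 mg/kg by the intraperitoneal route; a higher number here means more inhibition at the dose given (going by the name of the read-out), a lower number less inhibition. Compound 1 `CN1C/C(=C\c2ccccc2)C(=O)[C@]2(C1)[C@@H](c1ccccc1)CN(C)[C@@]21C(=O)Nc2ccccc21` gives 71.4%. Compound 2 `CN1C/C(=C\c2ccc(Cl)cc2)C(=O)[C@]2(C1)[C@@H](c1ccc(Cl)cc1)CN(C)[C@@]21C(=O)N(C)c2ccccc21` gives 44.5%. Compound 3 `Cc1ccc(/C=C2\CN(C)C[C@@]3(C2=O)[C@@H](c2ccc(C)cc2)CN(C)[C@@]32C(=O)Nc3ccccc32)cc1` gives 50.9%. Among these three numbers compound 3 stands second highest: its nearest neighbour is compound 2, whose number lies lower by an amount within the usual scatter, so the two cannot be told apart, while compound 1 lies higher by a margin beyond the scatter.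

Compound 4 `Cc1ccc(/C=C2\CN(C)C[C@@]3(C2=O)[C@@H](c2ccc(C)cc2)CN(C)[C@@]32C(=O)N(C)c3ccccc32)cc1` has not yet been measured. It differs from compound 3 in a single place: methyl in place of hydrogen on an amide-type nitrogen in a ring. Among the compounds with values here, no pair of measured compounds differs in exactly this one place, so no measured step shows what the change does by itself. Compound 2 also carries a methyl on this nitrogen, but it carries chlorine rather than methyl on its two benzene rings, so its number reflects both changes together. The step of a number 4.9 percentage points lower from compound 3 to compound 4 (within the scatter) is expected to be small, if anything slightly downward, and to stay within the scatter. Compound 4 is therefore expected to give about 46%, with a likely range from 32% to 60%.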

Compound 4, a percentage reported as inhibition, in the whole organism at one dose (the size of the read-out at that dose, not a potency): 65%
Beside the measured number, compound 4's estimate is 19 percentage points below it; measured number above the stated range.
By their numbers in this assay, from the lowest: compounds 2 and 3 (each within the scatter of the next); then compounds 4 and 1 (each within the scatter of the next).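

In this assay, the effect of this one change can now be read directly: methyl in place of hydrogen on the amide-type nitrogen in a ring gives a number 14.1 percentage points higher from compound 3 to compound 4 (beyond the scatter) with the rest of the structure unchanged. This position on the shared core therefore affects the read-out, and with methyl on both benzene rings, the amide hydrogen is not needed for inhibition at this dose. Nothing available here explains how the methyl produces this step.

The compounds shown leave open whether a longer chain such as ethyl, or a larger group such as benzyl, on this nitrogen would move the number further in the same direction. They also leave open whether the methyl step carries over when the two benzene rings bear chlorine or no added group.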